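This account rests on a few compounds, and the source may have more. Where it says the series, first, only, none or still open, it means among the compounds named here.

Measured so far:
compound 1, `C#Cc1ccccc1NC(=O)CCc1cccc2c1B(O)OC2`: 1300 nM
compound 2, `O=C(CCc1cccc2c1B(O)OC2)Nc1cccc(-c2cccc(Cl)c2)c1`: 250 nM

Within the data shown here, in a functional assay on MDA-MB-231 cells (Homo sapiens) for antiproliferative activity, read by MTT assay, with a stated time of 72 h (a lower number here means a stronger inhibitor, a higher number a weaker inhibitor), compound 2 gives 250 nM and stands with the lowest of the two numbers; its only neighbour, compound 1, gives 1300 nM in this assay, a gap that lies beyond the scatter. The next compound, compound 3, `CC(=O)c1cccc(-c2cccc(NC(=O)CCc3cccc4c3B(O)OC4)c2)c1`, has not yet been measured in this assay. It differs from compound 2 in one place: acetyl in place of chloro on an aromatic carbon. Among the measured compounds shown here, no measured pair in this set shows what such an exchange does, so the size of the step can only be guessed from the change itself. Compound 3 is expected to land close to compound 2, with at most a modest loss, giving a step of a 1.6-fold higher number from compound 2 to compound 3 (0.20 log units; within the scatter) in this assay. The value of compound 3 in this assay is therefore estimated at 400 nM, within a range of 150 nM to 1200 nM.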

Compound 3, half-maximal inhibitory concentration: 52 nM
The estimate for compound 3 lay 7.7-fold (0.89 log units) above the measured number; measured number outside the range, below it.
By their numbers in this assay, from the lowest: compound 3; then compound 2; then compound 1.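

In this assay, acetyl in place of chloro on this aromatic carbon, meta to a large group, gives a 4.8-fold lower number from compound 2 to compound 3 (0.68 log units; beyond the scatter). This shows that the position responds to what it carries, and that the larger acetyl, with its double bond outside the ring and its hydrogen-bond acceptor, is accompanied by a lower number rather than a higher one. No measurement shown here accounts for this step.

The compounds shown leave open whether the lower number belongs to acetyl alone or extends to other groups at this place, such as a primary amide, a carboxylic acid, a methyl ester or a hydroxymethyl group. They also leave open whether acetyl would give a similar number on another carbon of the same ring.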